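A few compounds are considered here, and "the series" means these few. Any claim that something is new, unique, unknown or untested is made for them only; others in the source may bear on it.

Measured in a functional assay on HL-60 cells (Homo sapiens) for inhibition, read by CCK-8 assay, with a stated time of 48 h, tested at 20 uM; on this read-out higher numbers stand for more inhibition of growth at the one concentration tested and lower numbers for less inhibition of growth:
- compound 1 `Cc1ccc(S(=O)(=O)Oc2ccccc2/C=C(\C#N)C(=O)Nc2nnc(C)s2)cc1`: 78%
- compound 2 `N#C/C(=C\c1ccccc1OS(=O)(=O)c1ccccc1[N+](=O)[O-])C(=O)Nc1nnc(Cc2ccc(F)cc2)s1`: 35%

Compound 1 stands highest of the two, and compound 2 lies below it by a gap beyond the scatter. Compound 3 `Cc1ccc(Cc2nnc(NC(=O)/C(C#N)=C/c3ccccc3OS(=O)(=O)c3ccc(C)cc3)s2)cc1` departs from compound 1 by 4-methylphenyl in place of hydrogen on a saturated chain carbon bound to an aromatic carbon. Going by the values given here, no measured pair isolates this change, so any expectation is loose. Among the compounds with values here, the only lower reference is compound 2 at 35%. In this assay a fall beyond the scatter is expected, an estimated step of a number 23 percentage points lower from compound 1 to compound 3 (beyond the scatter). For compound 3 the estimated value is 55%, with an expected range of 30% to 80%.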

Compound 3, percent growth inhibition at one concentration: 17%
Compound 3: middle estimate off by 38 percentage points, on the high side; the whole stated range lies above it.
By their numbers in this assay, from the lowest: compound 3; then compound 2; then compound 1.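

In this assay, going by these compounds alone, the first one-place step reads a number 61 percentage points lower from compound 1 to compound 3 (beyond the scatter), with methyl going to 4-methylbenzyl. At this position, then, the 4-methylphenyl group is poorly tolerated on the core of compound 1, and the methyl is the better of the two groups. Nothing measured here bears on the reason for this loss. Still open, going by these compounds, is whether the loss needs the whole 4-methylbenzyl group or appears with any growth at this carbon. An ethyl or an aminomethyl group there would separate these two readings.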